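The source may hold more compounds than are shown below. What is called first, only, known or untested is meant among the compounds shown, and "the series" means these compounds.

Measured so far:
- compound 1, `COc1cc2c(Oc3ccc(NC(=O)c4nn(-c5ccc([N+](=O)[O-])cc5)c(=O)c5ccccc45)cc3F)ccnc2cc1OCCCN1CCCCC1`: 2170 nM
- compound 2, `COc1cc2c(Oc3ccc(NC(=O)c4nn(-c5ccccc5Br)c(=O)c5ccccc45)cc3F)ccnc2cc1OCCCN1CCC(C)CC1`: 950 nM

Both numbers come from a functional assay on HT-29 cells (Homo sapiens) for cytotoxicity, read by MTT assay, with a stated time of 72 h; a higher number here means a weaker inhibitor, a lower number a stronger inhibitor. Among the two, compound 2 stands at the lower end with 950 nM, while compound 1 sits at 2170 nM, a gap beyond the usual scatter. The two compounds differ in two places at once, the group on the aromatic nitrogen of the shared core and the ring at the far end of the chain, so the numbers alone do not tell which change carries the gap.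

Compound 3, `COc1cc2c(Oc3ccc(NC(=O)c4nn(-c5ccc([N+](=O)[O-])cc5)c(=O)c5ccccc45)cc3F)ccnc2cc1OCCCN1CCC(C)CC1`, has not been measured. It changes only one of those places: 4-nitrophenyl in place of 2-bromophenyl on an aromatic nitrogen. Among the measured compounds shown here, the group that enters is the one carried by compound 1, which gives 2170 nM, and the remaining part of compound 3 matches compound 2, which gives 950 nM.

Against that background, the step of a 1.7-fold higher number from compound 2 to compound 3 (0.23 log units; within the scatter) is expected to run toward a higher number, of a size that may just pass the scatter. Compound 3 is estimated at 1600 nM, within a range from 700 nM to 3600 nM.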

Compound 3, half-maximal inhibitory concentration: 2450 nM
The estimate for compound 3 lay 1.5-fold (0.19 log units) below the measured number; the range from low to high includes it.
By their numbers in this assay, from the lowest: compound 2; then compounds 1 and 3 (each within the scatter of the next).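

In this assay, a 2.6-fold higher number from compound 2 to compound 3 (0.41 log units; beyond the scatter) when 4-nitrophenyl replaces 2-bromophenyl on the aromatic nitrogen of the shared core, so this position now has a single-place comparison, and the change there lies beyond the scatter. By contrast, methyl in place of hydrogen on a saturated ring carbon gives a 1.1-fold higher number from compound 1 to compound 3 (0.05 log units; within the scatter), which is within the scatter, so with 4-nitrophenyl on the nitrogen this methyl leaves no readable mark on the number, and of the two places that separate compound 1 from compound 2, only the group on the nitrogen has shown a step beyond the scatter. Nothing available here gives a reason for the step at the nitrogen.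

The two groups at this position differ both in what the phenyl ring carries and in where it carries it, so the step cannot be assigned to either difference, and a plain phenyl or a phenyl bearing an amine or a methoxy group could fall anywhere relative to these values. It also remains open whether the methyl would stay just as silent with 2-bromophenyl on the nitrogen, since that pair is not among the compounds shown.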